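This account rests on a few compounds, and the source may have more. Where it says the series, first, only, none or still open, it means among the compounds named here.

Among the measured compounds shown here, compound 1 `COc1ccc(CNC(=O)/C(C#N)=C/c2ccc(Cl)o2)cc1` is the only member of this small set with a definite number: in a functional assay on BE(2)-C cells (Homo sapiens) for inhibition, read by MTT assay, with a stated time of 72 h (on this read-out lower numbers stand for stronger inhibition of growth and higher numbers for weaker inhibition of growth), compound 1 gives 11000 nM. Compound 2 `COc1ccc(CNC(=O)/C(C#N)=C/c2ccc(-c3ccccc3)o2)cc1` reaches only a limit of the assay, > 100000 nM in this assay. For the measured compounds named here, the single measured step, an at least 9.0-fold higher number from compound 1 to compound 2 (0.95 log units; beyond the scatter), shows phenyl in place of chloro weakening growth inhibition, though the limit of > 100000 nM in this assay, at which 1 of the 2 values shown sits, hides the full size of that step. Compound 3 `COc1ccc(CNC(=O)/C(C#N)=C/c2ccc(Cl)cc2)cc1` differs from compound 1 by 4-chlorophenyl in place of 5-chlorofuran-2-yl on a double-bonded chain carbon bound to a double-bonded chain carbon. Going by the values given here, no measured step alters this ring, so the phenyl step bears only loosely on it; a modest weakening is expected, a 1.8-fold higher number from compound 1 to compound 3 (0.26 log units; within the scatter). Compound 3 is estimated at 20000 nM, between 6000 nM and 70000 nM.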

Compound 3, concentration for 50% growth inhibition: 12000 nM
Compound 3: the middle estimate sits 1.7-fold (0.22 log units) above what was measured; the measured number falls inside the stated range.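

Where the earlier step changed only the group carried on the ring, this one exchanges the ring itself, and this assay shows a 1.1-fold higher number from compound 1 to compound 3 (0.04 log units; within the scatter). At this place, then, 5-chlorofuran-2-yl and 4-chlorophenyl cannot be told apart, so the hetero atom of the five-membered ring is not needed to keep this level of growth inhibition. Nothing measured here explains this match.

Still open, going by these compounds, is whether a pyridine ring at this place would do the same, and whether an amine or a carboxylic acid in place of the chlorine would keep this level.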